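Working notes: the step from compound 1 to compound 4

This account rests on a few compounds, and the source may have more. Where it says the series, first, only, none or still open, it means among the compounds named here.

Values in an ADME assay on MDBK cells (Bos taurus) for cytotoxicity, read by MTT assay; on this read-out lower numbers stand for higher toxicity in this test and higher numbers for lower toxicity in this test:
- compound 1 `OC[C@@H]1[C@@H](O)[C@H](O)[C@@H](O)CN1CCCCCCOc1cc(F)ccc1F` gives > 500000 nM (a limit, not a number)
- compound 2 `OC[C@@H]1[C@@H](O)[C@H](O)[C@@H](O)CN1CCCc1cccc(OC2CCCCC2)c1` gives 390000 nM
- compound 3 `CCCCC1CCC(OCCCCCCN2C[C@H](O)[C@@H](O)[C@H](O)[C@H]2CO)CC1` gives 190000 nM

Compound 1 stands only at a limit of the assay (the limit of > 500000 nM in this assay, at which 1 of the 3 values shown sits). Its true value is therefore not known, and any step from it can be read in one direction only.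

Compound 4 `CC1CC(OCCCCCCN2C[C@H](O)[C@@H](O)[C@H](O)[C@H]2CO)CC(C)(C)C1` keeps the core and chain of compound 1 and carries 3,3,5-trimethylcyclohexyl in place of 2,5-difluorophenyl on an oxygen on a saturated carbon. Within the data shown here, no pair of measured compounds differs in one place, so the expectation rests on the values alone.

Of the measured compounds, compound 3 comes closest to compound 4 in the group on that oxygen, and compound 3 gives 190000 nM in this assay. Compound 2 gives 390000 nM as a further numerical reference. A number for compound 4 is therefore expected in the same region, on the side of higher toxicity in this test.

As far as these compounds go, the expected change is an at least 2.2-fold lower number from compound 1 to compound 4 (0.35 log units; beyond the scatter), an estimate whose true size stays open while its starting point is a limit.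

For compound 4 the estimated value is 220000 nM, with an expected range from 90000 nM to 500000 nM.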

Compound 4, half-maximal cytotoxic concentration: 250000 nM
Estimate against measurement, compound 4: 1.1-fold (0.06 log units) below, and the stated range covers the measured number.
By their numbers in this assay, from the lowest: compounds 3, 4 and 2 (each within the scatter of the next, the first and the last beyond it). At a limit, above all of these: compound 1.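

With the core and chain of compound 1 held constant, 3,3,5-trimethylcyclohexyl in place of 2,5-difluorophenyl on an oxygen on a saturated carbon gives, in this assay, an at least 2.0-fold lower number from compound 1 to compound 4 (0.30 log units; that floor lies within the scatter), the first step read at this position. Compound 1 gives > 500000 nM, which is a limit and not a number. Compound 4 gives 250000 nM, so this group yields a number in this assay, yet the true size of the step stays open and the step can be read in one direction only: the limit of > 500000 nM in this assay, at which 1 of the 4 values shown sits.

The compounds shown leave open whether the lower number goes with the loss of the aromatic ring, the loss of the two fluorines or the arrival of the three methyl groups, all of which change together in this one step. Unsubstituted phenyl on the same oxygen would separate the fluorines from the ring, while a carboxylic acid on the ring or a longer chain would show how far this read-out follows changes beyond the carbon-only groups seen at this position.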